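The source may hold more compounds than are shown below. What is called first, only, known or untested is meant among the compounds shown, and "the series" means these compounds.

Of the compounds shown here, three built on one shared core have been tested in a functional assay for inhibition of sodium/hydrogen exchanger (Oryctolagus cuniculus); on this read-out lower numbers stand for stronger inhibition and higher numbers for weaker inhibition. Compound 1 `Cc1cc(Sc2cccc(Cl)c2)c(S(C)(=O)=O)cc1C(=O)N=C(N)N` gives 37 nM. Compound 2 `Cc1cc(Sc2ccccc2Cl)c(S(C)(=O)=O)cc1C(=O)N=C(N)N` gives 14 nM. Compound 3 `Cc1cc(Oc2cccc(Cl)c2)c(S(C)(=O)=O)cc1C(=O)N=C(N)N` gives 21 nM. Among these three numbers compound 3 stands second highest: its nearest neighbour is compound 2, with a 1.5-fold higher number from compound 2 to compound 3 (0.18 log units; within the scatter), and its furthest is compound 1, with a 1.8-fold lower number from compound 1 to compound 3 (0.25 log units; within the scatter), so both gaps sit within the scatter. Going by the values given here, the only step beyond the scatter is a 2.6-fold lower number from compound 1 to compound 2 (0.42 log units; beyond the scatter), which puts 2-chlorophenyl in place of 3-chlorophenyl on a sulfur.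

Compound 4 `Cc1cc(Nc2ccccc2)c(S(C)(=O)=O)cc1C(=O)N=C(N)N` has not yet been measured. It differs from compound 3 in a single place: anilino in place of 3-chlorophenoxy on an aromatic carbon. Two measured steps speak to the linking atom, a 1.8-fold lower number from compound 1 to compound 3 (0.25 log units; within the scatter) and a 1.5-fold higher number from compound 2 to compound 3 (0.18 log units; within the scatter), and both stayed within the scatter, so exchanging the linker on its own gives no reason to expect a large move. Among the compounds with values here, no measured pair removes the chlorine altogether, so that part of the change has no precedent here. Compound 4 is therefore expected to give 40 nM, with a range from 12 nM to 130 nM. That estimate means a 1.9-fold higher number from compound 3 to compound 4 (0.28 log units; within the scatter), a step expected to remain within the scatter.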

Compound 4, half-maximal inhibitory concentration: 21 nM
The estimate for compound 4 lay 1.9-fold (0.28 log units) above the measured number; low and high end bracket the measured number.
By their numbers in this assay, from the lowest: compounds 2, 3, 4 and 1 (each within the scatter of the next, the first and the last beyond it).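

In this assay, putting anilino in place of 3-chlorophenoxy on the aromatic carbon ortho to a methylsulfonyl group gives no change at the digits printed from compound 3 to compound 4 (within the scatter); this single swap changes the linking atom, removes the chlorine and brings in a hydrogen-bond donor where the leaving group has none, yet the number stays within the scatter. The two other steps, a 1.5-fold higher number from compound 2 to compound 4 (0.18 log units; within the scatter) and a 1.8-fold lower number from compound 1 to compound 4 (0.25 log units; within the scatter), also stay within the scatter, so compound 4 cannot be told apart from either compound 1 or compound 2, even though those two lie beyond the scatter of each other. Nothing in the data shown bears on what lies behind this result.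

The compounds shown leave open how much of the step belongs to the linking nitrogen and how much to the loss of the chlorine, a split that a 3-chloroanilino or a plain phenoxy group on the same carbon would address. They also leave open how this position responds to a group with no aromatic ring on its linking atom, such as a piperidine or a short alkylamine.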